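Series notes: a second chloro on the aryl ring of compound 3

The source may report more compounds than this note shows. Statements on the series, on what has been measured and on what is new or still open speak of the compounds shown alone.

Compound 1 `N#C/C(=C\N1CCN(C(=O)c2ccco2)C1=S)C(=O)Nc1ccc(Cl)cc1`: 17800 nM in a functional assay on SF-268 cells (Homo sapiens) for inhibition, read by sulforhodamine B assay, with a stated time of 48 h; a lower number here means a stronger inhibitor of growth, a higher number a weaker inhibitor of growth
Compound 2 `N#C/C(=C\N1CCN(C(=O)c2ccco2)C1=S)C(=O)c1ccccc1`: 31200 nM in this assay
Compound 3 `O=CN1CCN(c2ccc(Cl)cc2)C1=S`: 19200 nM in this assay

Compound 3 holds the second highest of the three numbers; its value and that of compound 1 lie within the scatter of each other, and the same holds for its value against compound 2. Compound 4 `O=CN1CCN(c2ccc(Cl)c(Cl)c2)C1=S` differs from compound 3 by chloro in place of hydrogen on an aromatic carbon. Going by the values given here, the single measured step, a 1.8-fold higher number from compound 1 to compound 2 (0.24 log units; within the scatter), changes a different part of the molecule and is itself within the scatter, so it says nothing about a chloro added to the aromatic ring. Among the compounds with values here, no measured step bears on this change. The expected step is therefore a 1.2-fold lower number from compound 3 to compound 4 (0.08 log units; within the scatter) in this assay, with nothing beyond the scatter anticipated. Compound 4 is estimated at 16000 nM, with a range from 6000 nM to 45000 nM.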

Compound 4, concentration for 50% growth inhibition: 22200 nM
Estimate against measurement, compound 4: 1.4-fold (0.14 log units) below; measured number inside the range.
By their numbers in this assay, from the lowest: compounds 1, 3, 4 and 2 (each within the scatter of the next).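

Chloro in place of hydrogen on this aromatic carbon, ortho to a chloro group, gives a 1.2-fold higher number from compound 3 to compound 4 (0.06 log units; within the scatter) in this assay and so leaves compound 3 and compound 4 within the scatter of each other. Going by these compounds alone, the earlier compounds held no measured change on this ring, and this is the first reading for the position. Nothing available gives a reason for this result. Going by these compounds, whether an amine or a carboxylic acid on this carbon would give a step beyond the scatter remains open.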